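The source may hold more compounds than are shown below. What is called first, only, known or untested is meant among the compounds shown, and "the series" means these compounds.

Of the compounds shown here, three have been read so far in an ADME assay on HCT-116 cells (Homo sapiens) for cytotoxicity, read by CellTiter-Glo, with a stated time of 72 h (on this read-out lower numbers stand for stronger inhibition and higher numbers for weaker inhibition), and none of them gives a number. Compound 1 `Cc1cc(C)c(S(=O)(=O)N2CCN(C3CN4CCC3CC4)CC2)c(C)c1` gives > 5000 nM, which is a limit of the assay. Compound 3 `COc1ccccc1-c1cccc(S(=O)(=O)N2CCC(N3CCC(C)CC3)CC2)c1` gives > 5000 nM, also a limit. Compound 2 `CC1CCN(C2CCN(S(=O)(=O)c3cccnc3Cl)CC2)CC1` gives > 10000 nM, again a limit. Compound 2 therefore stands at the limit of > 10000 nM in this assay, at which 1 of the 3 values shown sits. Compound 1 and compound 3 stand at the limit of > 5000 nM in this assay, at which 2 of the 3 values shown sit. Going by the values given here, these limits are not numbers, so no order among the three compounds can be read from them, and no step between measured compounds is available to size a change.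

Compound 4 `CC1CCN(C2CCN(S(=O)(=O)c3cnc(Cl)s3)CC2)CC1` differs from compound 2 in one place: 2-chloro-1,3-thiazol-5-yl in place of 2-chloropyridin-3-yl on a sulfonyl sulfur. It carries 2-chloro-1,3-thiazol-5-yl in place of 2-chloropyridin-3-yl on a sulfonyl sulfur. In this assay, among the compounds with values here, no step beyond the usual scatter is expected in either direction, and the series so far offers no measured number that would point to one. The expectation rests on compound 2 at > 10000 nM, a limit. The expected change, a number no higher from compound 2 to compound 4 (the limit leaves the size open), is accordingly not taken to exceed the scatter. Compound 4 is estimated at 10000 nM, with an expected range of 4000 nM to 25000 nM, and a report of only a limit is the likeliest outcome.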

Compound 4, half-maximal inhibitory concentration: > 10000 nM
Compound 4: no number, only a limit (the forecaster's own chance of this, stated with the estimate: 85%); the middle value sits exactly at the limit.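

The step from compound 2 to compound 4, 2-chloro-1,3-thiazol-5-yl in place of 2-chloropyridin-3-yl on a sulfonyl sulfur, cannot be read: both compounds give only a limit in this assay. The compounds shown leave open whether any change at this place gives a measurable half-maximal inhibitory concentration.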